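This account rests on a few compounds, and the source may have more. Where it says the series, first, only, none or still open, it means among the compounds named here.

Measured so far:
- compound 1, `COc1cccc(CSc2nnc([C@@H](C)c3ccc4cc(OC)ccc4c3)n2-c2ccc(F)cc2)c1`: 19200 nM
- compound 2, `COc1ccc2cc([C@H](C)c3nnc(SCc4c(Cl)cccc4Cl)n3-c3cccc(Cl)c3)ccc2c1`: <= 400000 nM

Among the compounds with values here, compound 1 gives the only plain number in a functional assay on DU-145 cells (Homo sapiens) for cytotoxicity, read by MTT assay (a higher number here means a weaker inhibitor, a lower number a stronger inhibitor), 19200 nM. Compound 2 is known only through a limit of this assay, <= 400000 nM; this value is a limit and not a measured number (the limit of <= 400000 nM in this assay, at which 1 of the 2 values shown sits).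

Compound 3, `COc1ccc2cc([C@H](C)c3nnc(SCc4ccc(Cl)cc4)n3-c3ccc(F)cc3)ccc2c1`, has not yet been measured. It differs from compound 1 by 4-chlorophenyl in place of 3-methoxyphenyl on a saturated chain carbon bound to a sulfur. Within the data shown here, no measured pair shows the effect of such a change, so the step is expected to stay small, within the usual scatter, in either direction: a 1.3-fold lower number from compound 1 to compound 3 (0.11 log units; within the scatter). Compound 3 is therefore estimated at 15000 nM, with a range from 5000 nM to 45000 nM.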

Compound 3, half-maximal inhibitory concentration: 57400 nM
Compound 3: the middle estimate sits 3.8-fold (0.58 log units) below what was measured; measured number outside the range, above it.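

In this assay, within the data shown here, placing 4-chlorophenyl in place of 3-methoxyphenyl on a saturated chain carbon bound to a sulfur gives a 3.0-fold higher number from compound 1 to compound 3 (0.48 log units; beyond the scatter), the first measured step here. This position therefore responds to a change of its aryl group, and this swap gives a weaker inhibitor. Nothing shown accounts for the shift.

The compounds shown leave open whether the swapped substituent or its place on the ring drives the step, which 4-methoxyphenyl or 3-chlorophenyl could separate. On these data alone, how an amine or a carboxylic acid on that ring would read also remains open.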